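Octyl-side stereoisomer in the antiproliferative series

A few compounds are considered here, and "the series" means these few. Any claim that something is new, unique, unknown or untested is made for them only; others in the source may bear on it.

Values in a functional assay on A549 cells (Homo sapiens) for antiproliferative activity, read by MTT assay, with a stated time of 72 h; a lower number here means a stronger inhibitor, a higher number a weaker inhibitor:
- compound 1 `CCCCCCCCNC[C@@H]1OC[C@H](N)[C@@H]1O`: > 128000 nM, a limit of the assay
- compound 2 `CCCCCCCCCCCNC[C@@H]1OC[C@H](N)[C@@H]1O`: 11100 nM
- compound 3 `CCCCCCCCNC[C@@H]1OC[C@H](N)[C@H]1O`: not yet measured

Compound 1 has no number, only (the limit of > 128000 nM in this assay, at which 1 of the 2 values shown sits). The change to compound 3 is purely one of configuration: the two compounds have the same atoms and bonds and differ only in configuration as drawn: 1 of 3 stereo elements differ; a stereocentre at a saturated ring carbon is drawn S in compound 1 and R in compound 3.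

Among the measured compounds shown here, the one measured step is an at least 11-fold lower number from compound 1 to compound 2 (1.06 log units; beyond the scatter). That step is large, but it alters the chain and leaves the drawn configuration alone. For the measured compounds named here, no measured step therefore tests a change at a stereocentre, and its size cannot be carried over. Compound 3 keeps the chain of compound 1 and does not gain the extension seen in compound 2. From the compounds shown here alone, the direction of any shift in this assay stays open, and no step beyond the scatter is expected, with a modest drop the more likely outcome if one appears.

The expected step is an at least 1.0-fold lower number from compound 1 to compound 3 (0.02 log units; that floor lies within the scatter). The estimate for compound 3 is 120000 nM, with an expected range from 40000 nM to 200000 nM.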

Compound 3, half-maximal inhibitory concentration: 71800 nM
Compound 3: the middle estimate sits 1.7-fold (0.22 log units) above what was measured; measured number inside the range.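

Working notes on the series: the stereocentre at a saturated ring carbon, drawn S in compound 1 and R in compound 3, is tested here for the first time in this assay, and the step is an at least 1.7-fold lower number from compound 1 to compound 3 (0.25 log units; that floor lies within the scatter). Compound 1 gives > 128000 nM, which is a limit of the assay and not a number, so this step has a floor and no exact size: the limit of > 128000 nM in this assay, at which 1 of the 3 values shown sits. With the octyl chain unchanged, the shift to a measured value for compound 3 can be tied only to this one configuration change, though the floor of the step does not establish a real difference in potency: the fact that compounds 1 and 3 differ only in the configuration as drawn.

The compounds shown pair the R configuration at this carbon only with the octyl chain, so its effect with the longer chain of compound 2 remains open. Also open, from the compounds shown here alone, are the roles of the other two stereo elements, and what an acetamide in place of the primary amine would do in this assay.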